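The compounds below may be only part of what the source reports. "The series", "measured", "known", "first", "only" and "open" are said of these compounds alone.

In a functional assay for inhibition, with Homo sapiens as the target (a lower number here means a stronger inhibitor, a higher number a weaker inhibitor), compound 1 `CCCc1c(OCCCOc2ccc(C(=O)N(C)C)c(OC)c2CCC)ccc2c1OC(C(=O)O)CC2` gives < 0.14 nM, which is a limit of the assay and not a number. Its true potency is therefore not known. Two relatives give actual numbers: compound 2 `CCCc1c(OCCCOc2ccc(C(=O)NC)c(OC)c2CC2CC2)ccc2c1O[C@H](CCC(=O)O)CC2` gives 24.4 nM and compound 3 `CCCc1c(OCCCOc2ccc(C(=O)NC)c(OC)c2CC2CC2)ccc2c1OC(C(=O)O)CC2` gives 13 nM, but each differs from compound 1 in more than one place. Compound 4 `CCCc1c(OCCCOc2ccc(C(N)=O)c(OC)c2CCC)ccc2c1OC(C(=O)O)CC2` has amino in place of dimethylamino on a carbonyl carbon. Within the data shown here, no measured pair isolates this change, so any forecast is loose. A moderate loss of potency in this assay is expected, judging by compound 3 at 13 nM. The estimated step is an at least 10-fold higher number from compound 1 to compound 4 (1.02 log units; beyond the scatter). For compound 4 the estimated value is 1.5 nM, with an expected range from 0.1 nM to 20 nM.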

Compound 4, half-maximal inhibitory concentration: 2.7 nM
Compound 4: the middle estimate sits 1.8-fold (0.26 log units) below what was measured; low and high end bracket the measured number.
By their numbers in this assay, from the lowest: compound 4; then compounds 3 and 2 (each within the scatter of the next). At a limit, below all of these: compound 1.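

In this assay, compound 1 gives < 0.14 nM, which is a limit of the assay and not a number. Putting amino in place of dimethylamino on a carbonyl carbon gives an at least 19-fold higher number from compound 1 to compound 4 (1.28 log units; beyond the scatter), the first direct reading showing that the group at this position matters for potency. The true size of this step remains unknown because one end of it is a limit: the limit of < 0.14 nM in this assay, at which 1 of the 4 values shown sits.

The compounds shown leave open how methylamino would read on the core of compound 1, as compounds 2 and 3 carry it alongside other differences. Also open, as far as these compounds go, is how a pyrrolidine ring on this carbonyl carbon would read.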